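A few compounds are considered here, and "the series" means these few. Any claim that something is new, unique, unknown or untested is made for them only; others in the source may bear on it.

Measured so far:
compound 1, `COc1ccc(-c2ccc3c(NCCCNCc4cccc(OC)c4O)ccnc3c2)cc1`, in an ADME assay for permeability, using PAMPA, with a stated time of 30 min, at pH 7.4 (a lower number here means that the compound crosses the layer more slowly, a higher number that the compound crosses the layer faster), compound 1 gives 237 10^-6 cm/s
compound 2, `COc1cccc(CNCCCNc2ccnc3cc(C4CCCCC4)ccc23)c1O`, in this assay compound 2 gives 23 10^-6 cm/s
compound 3, `COc1cccc(Oc2ccc3c(NCCCNCc4cc(F)ccc4OC)ccnc3c2)c1`, in this assay compound 3 gives 317 10^-6 cm/s

Compound 3 shows the highest number of the three, but its gap to compound 1 lies within the scatter; only compound 2 stands clearly lower. Compound 4, `COc1cccc(Oc2ccc3c(NCCCNCc4cccc(OC)c4O)ccnc3c2)c1`, differs from compound 3 only in 2-hydroxy-3-methoxyphenyl in place of 5-fluoro-2-methoxyphenyl on a saturated chain carbon bound to an amine nitrogen. Among the compounds with values here, the one measured step, a 10-fold lower number from compound 1 to compound 2 (1.01 log units; beyond the scatter), concerns a different part of the molecule and does not bear on this change. Compound 1 already carries the entering group and sits within the scatter of compound 3, so no step beyond the scatter is expected, a 1.3-fold lower number from compound 3 to compound 4 (0.10 log units; within the scatter). Compound 4 is therefore estimated at 250 10^-6 cm/s, within a range of 120 10^-6 cm/s to 450 10^-6 cm/s.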

Compound 4, apparent permeability: 317 10^-6 cm/s
Beside the measured number, compound 4's estimate is 1.3-fold (0.10 log units) below it; the measured number falls inside the stated range.
By their numbers in this assay, from the lowest: compound 2; then compounds 1, 3 and 4 (each within the scatter of the next).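

In this assay there is no change at the digits printed from compound 3 to compound 4 (within the scatter) when 2-hydroxy-3-methoxyphenyl replaces 5-fluoro-2-methoxyphenyl, so with 3-methoxyphenoxy on the core, these two groups cannot be told apart on a saturated chain carbon bound to an amine nitrogen. On the aromatic carbon, replacing 4-methoxyphenyl with 3-methoxyphenoxy gives a 1.3-fold higher number from compound 1 to compound 4 (0.13 log units; within the scatter) and stays close, while replacing cyclohexyl with it gives a 14-fold higher number from compound 2 to compound 4 (1.14 log units; beyond the scatter) and marks compound 2 as the clear outlier. No supporting measurement explains these results. As far as these compounds go, whether a carboxylic acid or a simple amine in place of the aromatic ring on that chain carbon would shift the number remains open.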